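Three solubility limits and a cyclopropyl amide

The compounds below may be only part of what the source reports. "The series", "measured", "known", "first", "only" and "open" are said of these compounds alone.

Compound 1 `CN1CCC(C(=O)N2Cc3c(NC(=O)c4ccco4)n[nH]c3C2(C)C)CC1` sits at the assay limit of > 225000 nM in a physicochemical assay for solubility, at pH 7; on this read-out higher numbers stand for higher solubility and lower numbers for lower solubility.
Compound 2 `CCCNC(=O)Nc1n[nH]c2c1CN(C(=O)C1CCN(C)CC1)C2(C)C` gives only the limit > 225000 nM in this assay.
Compound 3 `CN1CCC(C(=O)N2Cc3c(NC(=O)c4cccc(F)c4)n[nH]c3C2(C)C)CC1` likewise gives only the limit > 225000 nM in this assay.

Compound 3 therefore stands at a limit, not at a number, and the other two values shown are limits as well; all three sit at the limit of > 225000 nM in this assay, at which 3 of the 3 values shown sit. Compound 4 `CN1CCC(C(=O)N2Cc3c(NC(=O)C4CC4)n[nH]c3C2(C)C)CC1` differs from compound 3 by cyclopropyl in place of 3-fluorophenyl on a carbonyl carbon.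

The measured steps that touch the carbonyl substituent all exchange one group for another at the same place: a step that the two limits leave unreadable from compound 1 to compound 2, a step that the two limits leave unreadable from compound 1 to compound 3 and a step that the two limits leave unreadable from compound 2 to compound 3. None of them can be read, since both ends of each sit at the limit in this assay. They show only that furan-2-yl, propylamino and 3-fluorophenyl on this carbonyl carbon all leave the compound at the limit.

With a smaller carbon-only ring entering, compound 4 is expected to remain at the limit too, so the expected step of a number no higher from compound 3 to compound 4 (the limit leaves the size open) is none beyond the scatter. In this assay compound 4 is estimated at 225000 nM, in a range from 110000 nM to 450000 nM.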

Compound 4, solubility: > 225000 nM
Compound 4: no number, only a limit; the forecaster's own chance of this, stated with the estimate: 85%; the middle value sits exactly at the limit.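

In this assay compound 4 gives > 225000 nM, which is a limit and not a number. Its steps from compound 1, compound 2 and compound 3 therefore cannot be read, and all four compounds sit at one limit: the limit of > 225000 nM in this assay, at which 4 of the 4 values shown sit. The compounds shown leave open how their solubilities compare, and whether any group on this carbonyl carbon would give a measurable number.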